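A few compounds are considered here, and "the series" means these few. Any claim that something is new, unique, unknown or untested is made for them only; others in the source may bear on it.

The measured compounds in this study:

Compound 2 `COc1ccc(-c2nc3sc(-c4ccc(Cl)cc4)cn3n2)cc1`: 34.9%
Compound 3 `COc1cc(-c2nc3sc(-c4ccccc4)cn3n2)cc(OC)c1OC`: 9%
Compound 1 `c1ccc(-c2nc3sc(-c4ccccc4)cn3n2)cc1`: 7%

In a functional assay on SF-268 cells (Homo sapiens) for inhibition, read by sulforhodamine B assay, with a stated time of 48 h, tested at 10 uM (a lower number here means less inhibition of growth, a higher number more inhibition of growth at the concentration tested), compound 2 stands at the top of the three numbers. Its nearest neighbour, compound 3, gives 9%, which lies beyond the scatter below it; the furthest, compound 1, gives 7%, also beyond the scatter below. Compound 4 `Clc1ccc(-c2cn3nc(-c4ccccc4)nc3s2)cc1` is reached from compound 2 by a single change: hydrogen in place of methoxy on an aromatic carbon. Within the data shown here, no pair of measured compounds differs in one place only, so the weight of the methoxy on its own is not isolated in the data. Compound 1, which carries neither the methoxy nor the chloro of compound 2, sits far below it, while compound 3 with three methoxy groups sits low as well, so the methoxy alone cannot be credited with the higher number of compound 2. A downward step in this assay is expected for compound 4, of moderate size, a number 14.9 percentage points lower from compound 2 to compound 4 (beyond the scatter). Compound 4 is thus estimated at 20%, within a range from 5% to 38%.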

Compound 4, percent growth inhibition at one concentration: 20%
Compound 4: middle estimate and measured number agree at the digits printed; low and high end bracket the measured number.
By their numbers in this assay, from the lowest: compounds 1 and 3 (each within the scatter of the next); then compound 4; then compound 2.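

In this assay the methoxy on an aromatic carbon, para to a large group, now has a step of its own: taking it away for hydrogen gives a number 14.9 percentage points lower from compound 2 to compound 4 (beyond the scatter). The chloro also has its own step, with chloro in place of hydrogen on an aromatic carbon giving a number 13 percentage points higher from compound 1 to compound 4 (beyond the scatter), so each of the two groups of compound 2 is now tied to a higher number and the methoxy is no longer the only candidate. Nothing at hand explains either step.

As far as these compounds go, it remains open whether a hydroxy group or an amine at the same place would hold the number of compound 2 or fall to that of compound 4, and whether a longer chain on the oxygen would change it further. From the compounds shown here alone, it is also open whether the methoxy step would have the same size on a compound that lacks the chloro.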